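The compounds below may be only part of what the source reports. "The series", "measured", "known", "first", "only" and "open" are said of these compounds alone.

In a physicochemical assay for solubility, in phosphate buffer, at pH 7.4 (a higher number here means a more soluble compound, a lower number a less soluble compound), compound 1 `OCCC1CCN(c2nccnc2OC2CN(c3ccc4ccccc4n3)C2)CC1` gives 84000 nM, while compound 2 `c1ccc(-c2nccnc2OC2CN(c3ccc4ccccc4n3)C2)nc1` gives 349000 nM, the highest of the two numbers. Compound 3 `c1ccc2nc(N3CC(Oc4nccnc4-c4cncnc4)C3)ccc2c1` carries pyrimidin-5-yl in place of pyridin-2-yl on an aromatic carbon. Within the data shown here, only one measured step bears on this change, and only loosely: the modest 4.2-fold higher number from compound 1 to compound 2 (0.62 log units; beyond the scatter) involved the departure of 4-(2-hydroxyethyl)piperidin-1-yl, not an exchange between six-membered aromatic rings. No step beyond the scatter is therefore expected in this assay. The estimated step is a 1.1-fold lower number from compound 2 to compound 3 (0.04 log units; within the scatter). Compound 3 is expected at 320000 nM, within an estimated range of 130000 nM to 750000 nM.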

Compound 3, solubility: 254000 nM
Beside the measured number, compound 3's estimate is 1.3-fold (0.10 log units) above it, and the stated range covers the measured number.
By their numbers in this assay, from the lowest: compound 1; then compounds 3 and 2 (each within the scatter of the next).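

In this assay the exchange of pyridin-2-yl for pyrimidin-5-yl gives a 1.4-fold lower number from compound 2 to compound 3 (0.14 log units; within the scatter) on this aromatic carbon, so this swap between six-membered aromatic rings stays within the scatter. Pyrimidin-5-yl in place of 4-(2-hydroxyethyl)piperidin-1-yl gives a 3.0-fold higher number from compound 1 to compound 3 (0.48 log units; beyond the scatter) and so stands beyond the scatter, as pyridin-2-yl did, which means the earlier step is not unique to one aromatic ring. No measurement offers an explanation for either step. Open, on these data alone, is where an open-chain amine or a carboxylic acid at this position would stand relative to these three compounds.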